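The compounds below may be only part of what the source reports. "The series", "measured", "known", "first", "only" and "open" are said of these compounds alone.

Compound 2 `Nc1nn2c(O)cc(-c3ccc(F)cc3)nc2c1[N+](=O)[O-]` stands in an ADME assay (Homo sapiens) for cytotoxicity (a lower number here means that less compound is tolerated, a higher number that more compound is tolerated), at > 100 ug/mL, which is a limit of the assay rather than a number. Compound 1 `Nc1nn2c(O)cc(-c3ccccc3)nc2c1[N+](=O)[O-]` gives > 100 ug/mL, again a limit. Compound 3 `Nc1nn2c(O)cc(CNNc3ccc(S(=O)(=O)O)cc3)nc2c1[N+](=O)[O-]` gives > 50 ug/mL, also a limit. The step that the two limits leave unreadable from compound 1 to compound 2 cannot be read in size or direction. All that the measured set offers is the limit of > 100 ug/mL in this assay, at which 2 of the 3 values shown sit, and (the limit of > 50 ug/mL in this assay, at which 1 of the 3 values shown sits). Compound 4 `CCSC(N)NCc1cc(O)n2nc(N)c([N+](=O)[O-])c2n1` carries ((amino(ethylsulfanyl)methyl)amino)methyl in place of 4-fluorophenyl on an aromatic carbon. No measured step bears on this change, so the only guide is that every compound shown was tolerated up to a limit. Compound 4 is therefore expected to sit near 100 ug/mL, between 40 ug/mL and 250 ug/mL. The step of a number no higher from compound 2 to compound 4 (the limit leaves the size open) that this estimate means is expected to stay within the scatter.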

Compound 4, half-maximal cytotoxic concentration: > 50 ug/mL
Compound 4: no number, only a limit; the forecaster's own chance of this, stated with the estimate: 65%; the middle value lies beyond the limit too.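

Compound 4 gives only a limit, as do compound 1 and compound 2, so the steps from those two compounds to compound 4 cannot be read in size or direction. The compounds shown leave open where the actual cytotoxic concentration of each lies: the limit of > 50 ug/mL in this assay, at which 2 of the 4 values shown sit.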